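The source may report more compounds than this note shows. Statements on the series, on what has been measured and on what is new or still open speak of the compounds shown alone.

In a functional assay on A549 cells (Homo sapiens) for cytotoxicity, read by MTT assay, with a stated time of 72 h (a lower number here means a stronger inhibitor, a higher number a weaker inhibitor), compound 1 (`O=C(Nc1nnc(-c2cccc(O)c2O)s1)c1ccc(Cl)cc1`) gives 9500 nM and compound 2 (`O=C(COc1ccccc1)Nc1nnc(-c2cccc(O)c2O)s1`) gives 10500 nM on the same shared core. These two values lie within the usual scatter of each other, so compound 2 stands level with compound 1 and neither can be ranked.

Compound 3 (`O=C(Nc1nnc(-c2cccc(O)c2O)s1)c1ccccc1`) has not yet been measured. It keeps the shared core and differs from compound 2 in one place, with phenyl in place of phenoxymethyl on a carbonyl carbon whose other neighbour is an amide-type nitrogen (phenyl in place of phenoxymethyl on a carbonyl carbon).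

Among the compounds with values here, one measured step bears on this change: a 1.1-fold higher number from compound 1 to compound 2 (0.04 log units; within the scatter) with phenoxymethyl in place of 4-chlorophenyl on that same carbonyl carbon. On that evidence, no step beyond the scatter is expected in this assay in either direction. A single step is thin support, so the range given here is kept wide.

As a number, the expected move (a 1.1-fold lower number from compound 2 to compound 3 (0.02 log units; within the scatter)) stays within the scatter. Compound 3 is therefore estimated at 10000 nM with an expected range from 4500 nM to 22000 nM for a measurement in this test.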

Compound 3, half-maximal inhibitory concentration: 12300 nM
Beside the measured number, compound 3's estimate is 1.2-fold (0.09 log units) below it, and the stated range covers the measured number.
By their numbers in this assay, from the lowest: compounds 1, 2 and 3 (each within the scatter of the next).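

In this assay, putting phenyl in place of phenoxymethyl on the carbonyl carbon gives a 1.2-fold higher number from compound 2 to compound 3 (0.07 log units; within the scatter), so the same aromatic ring, with or without the phenoxymethyl link to the carbonyl carbon, produces no readable difference. Within the data shown here, compound 3 also separates out the chloro group for the first time: hydrogen in place of chloro on an aromatic carbon gives a 1.3-fold higher number from compound 1 to compound 3 (0.11 log units; within the scatter), which means that this change cannot be read as a real difference either. Together, these steps show that none of the three groups tried on this carbonyl carbon can be ranked above another, and no supporting measurement is available to explain why the numbers stay so close.

All three compounds keep the shared core and carry a six-membered aromatic ring of carbon only at this place, so they cannot show how far this tolerance extends. As far as these compounds go, a longer chain, an amine or a carboxylic acid on this carbonyl carbon could behave quite differently, and what changes in the shared core itself would do also remains open.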